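The source may hold more compounds than are shown below. What is called first, only, known or untested is meant among the compounds shown, and "the series" means these compounds.

Measured so far in a physicochemical assay for solubility, using the shake flask method, measured as kinetic solubility, with a stated time of 20 h, at pH 2; a higher number here means a more soluble compound, a lower number a less soluble compound
Compound 1 `COc1cccnc1Nc1cc2[nH]c(-c3cccc(C(F)(F)F)c3)nc2cn1` gives 116000 nM
Compound 2 `Fc1ccc(Nc2cc3[nH]c(-c4cccc(C(F)(F)F)c4)nc3cn2)nc1` gives < 5000 nM
Compound 3 `FC(F)(F)c1ccc(Nc2cc3[nH]c(C4CCCC4)nc3cn2)nc1` gives 132000 nM

Compound 2 reports only a limit of the assay (< 5000 nM) and no number. Compound 3 at 132000 nM lies within the scatter of compound 1 at 116000 nM in this assay and has no number clearly apart from it. Compound 4 `FC(F)(F)c1ccc(Nc2cc3[nH]c(C4CC4)nc3cn2)nc1` carries cyclopropyl in place of cyclopentyl on an aromatic carbon. Going by the values given here, the one measured step (an at least 23-fold lower number from compound 1 to compound 2 (1.36 log units; beyond the scatter)) was large, but it exchanged a group on a nitrogen on an aromatic ring, so it bears only loosely on this change. Among the compounds with values here, no measured step touches the cyclopentyl group itself. No step beyond the scatter is therefore expected in this assay and neither direction is favoured. The expected step is small (a 1.1-fold higher number from compound 3 to compound 4 (0.06 log units; within the scatter)) and uncertain. Compound 4 is estimated at 150000 nM with an expected range (50000 nM to 400000 nM).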

Compound 4, solubility: 198000 nM
Compound 4: middle estimate off by 1.3-fold (0.12 log units), on the low side; low and high end bracket the measured number.
By their numbers in this assay, from the lowest: compounds 1, 3 and 4 (each within the scatter of the next). At a limit, below all of these: compound 2.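

In this assay cyclopropyl in place of cyclopentyl on an aromatic carbon between two ring nitrogen atoms gives a 1.5-fold higher number from compound 3 to compound 4 (0.18 log units; within the scatter) and so, unlike the large step at the other end of the core, the only step shown at this position stays within the scatter. Across this pair, the two carbon rings cannot be told apart in this assay. Nothing shown accounts for this step.

Still open, as far as these compounds go, is whether an amine, a carboxylic acid or a longer chain at this position would give a step beyond the scatter. From the compounds shown here alone, it also remains open whether the same exchange would give a similar step with the other groups on the shared core.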